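A Dichlorophenyl Swap on Compound 1

The source may hold more compounds than are shown below. What is called first, only, known or untested is meant among the compounds shown, and "the series" means these compounds.

In a functional assay on MCF7 cells (Homo sapiens) for antiproliferative activity, read by MTT assay (on this read-out higher numbers stand for weaker inhibition and lower numbers for stronger inhibition), three compounds have been measured. Compound 1 (`COc1ccc(-c2ccnc(Nc3ccc([N+](=O)[O-])cc3)n2)cc1`) gives 770 nM, the lowest number of the three and beyond the scatter from both others. Compound 2 (`COc1ccc(-c2ccnc(Nc3ccc(Cl)cc3Cl)n2)cc1`) gives 4170 nM, and compound 3 (`COc1cccc(Nc2nccc(-c3ccc(F)cc3)n2)c1`) gives 412000 nM.

Compound 4 (`O=[N+]([O-])c1ccc(Nc2nccc(-c3ccc(Cl)c(Cl)c3)n2)cc1`) departs from compound 1 in one place, with 3,4-dichlorophenyl in place of 4-methoxyphenyl on an aromatic carbon. Within the data shown here, no measured pair isolates this change, and the evidence for it is thin. Among the measured compounds shown here, compound 3, the only measured compound without the 4-methoxyphenyl, gives 412000 nM, but it also differs from compound 1 elsewhere. On that limited basis, a moderate rise in the number in this assay is expected, beyond the scatter and toward weaker inhibition. The expected step is a 3.9-fold higher number from compound 1 to compound 4 (0.59 log units; beyond the scatter). For compound 4, the estimated value is 3000 nM, with an expected range from 350 nM to 30000 nM.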

Compound 4, half-maximal inhibitory concentration: 3510 nM
Estimate against measurement, compound 4: 1.2-fold (0.07 log units) below, within the range that was stated.
By their numbers in this assay, from the lowest: compound 1; then compounds 4 and 2 (each within the scatter of the next); then compound 3.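

In this assay, among these compounds, this pair gives the first direct reading at this position: with the rest of the structure unchanged, putting 3,4-dichlorophenyl in place of 4-methoxyphenyl gives a 4.6-fold higher number from compound 1 to compound 4 (0.66 log units; beyond the scatter), a modest step toward weaker inhibition. The two groups have the same heavy-atom count but differ in their atoms and in the hydrogen-bond acceptor, and this single step cannot show which of these differences matters. Nothing measured here accounts for the step.

From the compounds shown here alone, it remains open whether a phenyl ring with one chlorine, or with an amine or a carboxylic acid, would give a number closer to that of compound 1. Going by these compounds, it is also open whether the same swap would give a similar step with the other end of the molecule as it stands in compound 2.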